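Branched furan-bearing side chain on the quinoline amide

The source may report more compounds than this note shows. Statements on the series, on what has been measured and on what is new or still open speak of the compounds shown alone.

Two compounds of this series are measured. Compound 1 `C[C@H](c1ccc(F)cc1)N(Cc1cccc(C(=O)O)c1)C(=O)c1cc2ccccn2n1` gives 94 nM in an assay on CHO T-rex cells for antagonist activity at transient receptor potential cation channel subfamily M member 8 (Homo sapiens), read by calcium flux, with a stated time of 20 min; on this read-out lower numbers stand for stronger inhibition and higher numbers for weaker inhibition. Compound 2 `O=C(O)c1cccc(CN(Cc2ccc(F)cc2)C(=O)c2cnc3ccccc3c2)c1` reaches only the limit of the assay, > 9350 nM, in this assay. Compound 2 therefore stands at the weak end of the two values shown, at the limit noted in the limit of > 9350 nM in this assay, at which 1 of the 2 values shown sits, and it is the starting point of the step followed here.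

Compound 3 `CC[C@H](c1ccc(C)o1)N(Cc1cccc(C(=O)O)c1)C(=O)c1cnc2ccccc2c1` differs from compound 2 in one place: 1-(5-methylfuran-2-yl)propyl in place of 4-fluorobenzyl on an amide-type nitrogen. No measured step of this kind exists among the two compounds shown, and compound 1 differs from compound 2 in more than one place. The value of compound 1, 94 nM, can therefore only loosely guide an expectation. Compound 3 is therefore expected to move toward stronger inhibition from the limit by an at least 6.2-fold lower number from compound 2 to compound 3 (0.79 log units; beyond the scatter), beyond the scatter but with wide uncertainty. Compound 3 is estimated at 1500 nM, within a range from 250 nM to 9350 nM in this assay.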

Compound 3, half-maximal inhibitory concentration: 328 nM
Beside the measured number, compound 3's estimate is 4.6-fold (0.66 log units) above it; measured number inside the range.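

For the compounds shown here, on the amide-type nitrogen, 1-(5-methylfuran-2-yl)propyl in place of 4-fluorobenzyl gives an at least 28-fold lower number from compound 2 to compound 3 (1.45 log units; beyond the scatter), the first measured single change and a large one in this assay. Compound 3 keeps the shared core and the carboxylic acid of compound 2, so this one position on the nitrogen is enough to bring that core from the assay limit to a measurable value. How large the step truly is cannot be read, because the value of compound 2 is a limit and not a number: the limit of > 9350 nM in this assay, at which 1 of the 3 values shown sits.

The change alters several things at once, since the entering group brings a five-membered aromatic ring with an oxygen, a methyl on that ring, a propyl-type branch and a defined stereocentre, and the compounds shown do not separate these. An unbranched (5-methylfuran-2-yl)methyl group, a 1-(4-fluorophenyl)propyl group and the mirror-image form of the 1-(5-methylfuran-2-yl)propyl group on the same nitrogen would each be needed to tell which of these parts carries the step.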